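Trading a Nitrile Tail for a Hydroxyl Tail

The source may hold more compounds than are shown below. What is called first, only, known or untested is meant among the compounds shown, and "the series" means these compounds.

Among the measured compounds shown here, compound 2 `C=CCc1cc(C(C)=O)c(O)cc1OCCCCC#N` is one of two compounds measured in an assay on isolated protein for binding affinity to leukotriene B4 receptor 1 (Homo sapiens), tested at 1 uM; on this read-out higher numbers stand for more inhibition at the one concentration tested (going by the name of the read-out) and lower numbers for less inhibition; there compound 2 gives 57%. Compound 1 `CCc1cc(C(C)=O)c(O)cc1OCCCCC#N` gives 57% in this assay, so compound 2 stands level with it, and the step of no change at the digits printed from compound 1 to compound 2 (within the scatter) was flat. Compound 3 `C=CCc1cc(C(C)=O)c(O)cc1OCCCCO` differs from compound 2 by hydroxy in place of cyano on a saturated chain carbon, four bonds along the chain from an oxygen on an aromatic ring. For the measured compounds named here, no measured step bears on a hydroxy in place of cyano; the only step measured lies elsewhere on the molecule. On that thin basis, compound 3 is expected to move by about a number 12 percentage points lower from compound 2 to compound 3 (beyond the scatter). The estimate for compound 3 is 45%, ranging from 15% to 75%.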

Compound 3, a percentage reported as inhibition, at one concentration (the size of the read-out at that concentration, not a potency): 9%
Beside the measured number, compound 3's estimate is 36 percentage points above it, outside the stated range (below it).
By their numbers in this assay, from the lowest: compound 3; then compounds 1 and 2 (each within the scatter of the next).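

In this assay, hydroxy in place of cyano on a saturated chain carbon, four bonds along the chain from an oxygen on an aromatic ring, moves the read-out a number 48 percentage points lower from compound 2 to compound 3 (beyond the scatter). Unlike the flat earlier step elsewhere on the molecule, this shows that the read-out responds strongly to what sits at the end of this chain. Nothing available here explains the drop. Still open, from the compounds shown here alone, is how a carboxylic acid or an amine at this chain end would read, and whether a longer chain carrying the nitrile would hold the value.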